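The source may hold more compounds than are shown below. What is called first, only, known or untested is meant among the compounds shown, and "the series" means these compounds.

Measured compounds:
compound 1 `CNCC(=O)N1N=C(c2cc3ccccc3oc2=O)CC1c1ccccc1` — 2300 nM in a functional assay on PC-3 cells (Homo sapiens) for cytotoxicity, read by MTT assay, with a stated time of 48 h; a lower number here means a stronger inhibitor, a higher number a weaker inhibitor
compound 2 `O=C(CNC1CCCCC1)N1N=C(c2cc3ccccc3oc2=O)CC1c1ccccc1` — 48500 nM in this assay

Among the measured compounds shown here, compound 2 stands at the highest of the two numbers recorded so far; the only other compound, compound 1, sits well apart from it, the step being a 21-fold higher number from compound 1 to compound 2 (1.32 log units; beyond the scatter), the change there being cyclohexyl in place of methyl on an amine nitrogen.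

Compound 3 `O=C(CN1CCC(O)CC1)N1N=C(c2cc3ccccc3oc2=O)CC1c1ccccc1` is not yet measured. Its difference from compound 2 is 4-hydroxypiperidin-1-yl in place of cyclohexylamino on a saturated chain carbon bound to a carbonyl carbon. For the measured compounds named here, no measured step covers this kind of change; the one step known, from compound 1 to compound 2, altered only what hangs on that amine nitrogen and raised the number markedly, while here the nitrogen becomes part of the six-membered ring itself and a hydroxyl is added. Going by the values given here, since the single measured step gives no direct guide, the expectation rests on compound 3 keeping a six-membered ring of similar size at the same place as compound 2, so a number of the same order is expected, with a wide range. The step expected from compound 2 to compound 3 is a 1.9-fold lower number from compound 2 to compound 3 (0.29 log units; within the scatter). Compound 3 is estimated at 25000 nM, within 5000 nM to 100000 nM.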

Compound 3, half-maximal inhibitory concentration: "not active" (no number reported)
Nothing numeric was reported for compound 3; the estimate stays without a comparison.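

Among the compounds shown here, compound 3 is recorded as "not active" in this assay with no number, so no step from compound 2 to compound 3 can be read. Nothing available bears on a cause for this result. The compounds shown leave open how 4-hydroxypiperidin-1-yl compares numerically with cyclohexylamino on a saturated chain carbon bound to a carbonyl carbon.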